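The source may report more compounds than this note shows. Statements on the series, on what has been measured and on what is new or still open speak of the compounds shown alone.

Measured so far:
compound 1 `O=C(/C=C\Nc1ccc(F)cc1)c1cn(-c2ccccc2)nc1-c1ccccc1` gives 7980 nM in a functional assay on PC-3 cells (Homo sapiens) for antiproliferative activity, read by MTT assay, with a stated time of 48 h; a higher number here means a weaker inhibitor, a lower number a stronger inhibitor.
compound 2 `O=C(/C=C\Nc1ccc(C(F)(F)F)cc1)c1cn(-c2ccccc2)nc1-c1ccccc1` reaches only the limit of this assay at > 50000 nM.
compound 3 `COc1ccc(N/C=C\C(=O)c2cn(-c3ccccc3)nc2-c2ccccc2)cc1` gives 6400 nM in this assay.

Of the two plain numbers compound 1 stands highest, with compound 3 nearest, yet the step of a 1.2-fold lower number from compound 1 to compound 3 (0.10 log units; within the scatter) lies within the scatter, so the two are not ordered. The remaining value is a limit (the limit of > 50000 nM in this assay, at which 1 of the 3 values shown sits). The measured steps all exchange the fluoro of compound 1 for another group on the same carbon: an at least 6.2-fold higher number from compound 1 to compound 2 (0.79 log units; beyond the scatter), and an at least 7.8-fold lower number from compound 2 to compound 3 (0.89 log units; beyond the scatter).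

Compound 4 `O=C(/C=C\Nc1ccc(F)cc1)c1cn(-c2ccccc2)nc1-c1ccc(F)cc1` differs from compound 1 by fluoro in place of hydrogen on an aromatic carbon; cut one bond further out the change reads phenyl to 4-fluorophenyl. For the measured compounds named here, the fluoro of compound 1 is kept in compound 4, and none of the measured steps touches the ring that now receives the new fluoro, so no measured step bears directly on this change. A single fluoro added to an aromatic carbon is a small change, and with no contrary evidence no step beyond the scatter is expected: a 1.1-fold lower number from compound 1 to compound 4 (0.06 log units; within the scatter). Compound 4 is therefore estimated at 7000 nM, within 2500 nM to 20000 nM.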

Compound 4, half-maximal inhibitory concentration: 7900 nM
For compound 4 the middle estimate is 1.1-fold (0.05 log units) below the measured one, within the range that was stated.
By their numbers in this assay, from the lowest: compounds 3, 4 and 1 (each within the scatter of the next). At a limit, above all of these: compound 2.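

Phenyl to 4-fluorophenyl is the first change shown at this position, away from the carbon varied in compounds 1, 2 and 3, and in this assay it gives a 1.0-fold lower number from compound 1 to compound 4 (0.00 log units; within the scatter). A fluoro on this aromatic carbon therefore produces no step beyond the scatter, so this position accepts at least this one small change, though a single pair shows nothing about other groups here. Nothing on hand bears on why the number holds.

Open, as far as these compounds go, is whether an amine or a carboxylic acid on this same carbon would also stay within the scatter of compound 1. Also open, from the compounds shown here alone, is whether trifluoromethyl here would end at a limit, as it does on the other ring in compound 2, and whether 4-fluorophenyl would behave the same with the methoxy of compound 3.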